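This account rests on a few compounds, and the source may have more. Where it says the series, first, only, none or still open, it means among the compounds named here.

Working notes on the series. Within the data shown here, compound 2 `C#CCN(Cc1nc2cc(C(F)(F)F)ccc2nc1-c1ccccc1)c1ccc(OC(F)(F)F)cc1` carries the highest of the two numbers so far in an assay on isolated protein for inhibition of Dihydrofolate reductase (Homo sapiens), read by spectrophotometry (on this read-out higher numbers stand for weaker inhibition and lower numbers for stronger inhibition), giving 4000 nM; its nearest neighbour is compound 1 `C#CCN(Cc1nc2cc(C(F)(F)F)ccc2nc1-c1ccccc1)c1ccc(OC)cc1`, which in this assay gives 3000 nM, and the step of a 1.3-fold higher number from compound 1 to compound 2 (0.12 log units; within the scatter) lies within the scatter. Compound 3 `C#CCN(Cc1nc2cc(C(F)(F)F)ccc2nc1-c1ccccc1)c1ccc(OC)c(OC)c1` is the next member to be measured; it differs from compound 2 by 3,4-dimethoxyphenyl in place of 4-(trifluoromethoxy)phenyl on an amine nitrogen. Among the measured compounds shown here, the only measured step that bears on this change is the one from compound 1 to compound 2, a trifluoromethyl in place of methyl on an oxygen on an aromatic ring, which moved the number by a 1.3-fold higher number from compound 1 to compound 2 (0.12 log units; within the scatter); no measured pair covers the second methoxy group that enters. On that basis the change to compound 3 is expected to give a small step in this assay, if any, tending toward a lower number, roughly a 1.6-fold lower number from compound 2 to compound 3 (0.20 log units; within the scatter). Compound 3 is accordingly estimated at 2500 nM, with a range from 800 nM to 8000 nM.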

Compound 3, inhibition constant: 3000 nM
Beside the measured number, compound 3's estimate is 1.2-fold (0.08 log units) below it; the measured number falls inside the stated range.
By their numbers in this assay, from the lowest: compounds 1, 3 and 2 (each within the scatter of the next).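

In this assay, the second methoxy group now has a measured pair of its own (no change at the digits printed from compound 1 to compound 3 (within the scatter)). The exchange of 4-(trifluoromethoxy)phenyl for 3,4-dimethoxyphenyl on an amine nitrogen, which changes the heavy-atom count and the hydrogen-bond acceptor count, also stays small (a 1.3-fold lower number from compound 2 to compound 3 (0.12 log units; within the scatter)), so all three aryl groups at this place lie within the scatter of one another. No measurement shown bears on why these changes leave the number within the scatter.

On these data alone, all three aryl groups carry only oxygen-linked substituents, so it remains open whether an amine or a carboxylic acid on the aromatic ring would move the number beyond the scatter. Also open, as far as these compounds go, is whether a saturated ring or a longer chain in place of the aryl group on the amine nitrogen would do so.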